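Trimming one methoxy from compound 1: an expectation

A few compounds are considered here, and "the series" means these few. Any claim that something is new, unique, unknown or untested is made for them only; others in the source may bear on it.

The series is judged in a functional assay on SF-268 cells (Homo sapiens) for inhibition, read by sulforhodamine B assay, with a stated time of 48 h; on this read-out lower numbers stand for stronger inhibition of growth and higher numbers for weaker inhibition of growth. Compound 1 `COc1cc(-c2cc(/C=C/C(=O)c3ccc(N)cc3)[nH]n2)cc(OC)c1OC` gives 1690 nM, the lowest of the three numbers recorded. Compound 2 `COc1ccc(-c2cc(/C=C/C(=O)c3ccc(OC)c(OC)c3)[nH]n2)cc1` gives 1940 nM, which lies within the scatter of compound 1, so the two cannot be ordered. Compound 3 `COc1cc(-c2cc(/C=C/C(=O)c3ccc(Cl)c(Cl)c3)[nH]n2)cc(OC)c1OC` gives 13700 nM, and the only single-point step among these, an 8.1-fold higher number from compound 1 to compound 3 (0.91 log units; beyond the scatter), concerns the group on the carbonyl carbon, not the part of the molecule at issue here.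

Compound 4 `COc1ccc(-c2cc(/C=C/C(=O)c3ccc(N)cc3)[nH]n2)cc1OC` differs from compound 1 by hydrogen in place of methoxy on an aromatic carbon. Going by the values given here, no measured pair isolates this change; the nearest guide is that compound 2, which also carries fewer methoxy groups on that six-membered aromatic ring of carbon only, sits within the scatter of compound 1 in this assay. On that basis compound 4 is expected to land close to compound 1, with the step of a 1.5-fold higher number from compound 1 to compound 4 (0.17 log units; within the scatter) estimated to stay near or just beyond the scatter. Compound 4 is estimated at 2500 nM, within a range of 900 nM to 7000 nM.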

Compound 4, concentration for 50% growth inhibition: 1890 nM
Compound 4: middle estimate off by 1.3-fold (0.12 log units), on the high side; measured number inside the range.
By their numbers in this assay, from the lowest: compounds 1, 4 and 2 (each within the scatter of the next); then compound 3.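

Going by these compounds alone, compound 4 gives the first direct reading of this change: hydrogen in place of methoxy on an aromatic carbon, ortho to a methoxy group and meta to a large group, yields a 1.1-fold higher number from compound 1 to compound 4 (0.05 log units; within the scatter) in this assay and leaves the two compounds unordered. With the 4-aminophenyl group kept on the carbonyl carbon, this methoxy, with its 2 heavy atoms and 1 hydrogen-bond acceptor, can therefore give way to hydrogen with the number staying within the scatter. No measurement at hand offers a reason for this result.

As far as these compounds go, whether the same holds with the 3,4-dichlorophenyl group of compound 3 on the carbonyl carbon remains open. Also open, from the compounds shown here alone, is how this position would respond to a group other than hydrogen or methoxy, such as a hydroxyl, a fluorine or an ethoxy.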